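The compounds below may be only part of what the source reports. "The series", "measured", "known", "first", "only" and "open" are said of these compounds alone.

Measured compounds:
compound 1 `C#C[C@@]1(O)[C@@H](CO)O[C@@H](n2cc(Cl)c3c(N)ncnc32)[C@@H]1O` with 14 nM;
compound 2 `C#C[C@@]1(O)[C@@H](CO)O[C@@H](n2cc(I)c3c(N)ncnc32)[C@@H]1O` with 56 nM;
compound 3 `C#C[C@@]1(O)[C@@H](CO)O[C@@H](n2cc(Cl)c3c(N)ccnc32)[C@@H]1O` with 980 nM.

In a functional assay on L1210 cells (Mus musculus) for antiproliferative activity, read by cell counting, with a stated time of 48 h (on this read-out lower numbers stand for stronger inhibition and higher numbers for weaker inhibition), compound 1 gives 14 nM and compound 2 gives 56 nM. The two differ in one place (iodo in place of chloro on an aromatic carbon), and this change made a step of a 4.0-fold higher number from compound 1 to compound 2 (0.60 log units; beyond the scatter). Compound 3, which gives 980 nM in this assay, stands highest of the three; against compound 2 its number is higher by a wide margin, and against compound 1 by a still wider one. Compound 3 and compound 1 differ by more than a single group, and the difference between the two cores is not broken down here.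

Compound 4 `C#C[C@@]1(O)[C@@H](CO)O[C@@H](n2cc(I)c3c(N)ccnc32)[C@@H]1O` has not yet been measured in this assay. It differs from compound 3 in one place (iodo in place of chloro on an aromatic carbon), and the place of the change is described in the same words for both pairs, so it is the same change that turned compound 1 into compound 2. That change occurs in both pairs and nowhere else among the compounds shown.

The expectation for compound 4 rests on compound 3 and on the step that this change made before, because a 4.0-fold higher number from compound 1 to compound 2 (0.60 log units; beyond the scatter) was beyond the scatter and in the upward direction. Going by the values given here, the step from compound 3 to compound 4 in this assay is therefore expected to be of about the same size, a 3.6-fold higher number from compound 3 to compound 4 (0.55 log units; beyond the scatter), though only one earlier instance supports it. For compound 4 the estimate in this assay is 3500 nM, with a range expected from 1200 nM to 10000 nM.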

Compound 4, half-maximal inhibitory concentration: 44 nM
For compound 4 the middle estimate is 80-fold (1.90 log units) above the measured one, and the stated range ends above it.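

In this assay, iodo in place of chloro on an aromatic carbon did not behave on the second core as it had on the first: the new pair shows a 22-fold lower number from compound 3 to compound 4 (1.35 log units; beyond the scatter), whereas the same change had gone upward on the core of compound 1, with a 4.0-fold higher number from compound 1 to compound 2 (0.60 log units; beyond the scatter). Set side by side, the two steps point in opposite directions, and the gap between them lies beyond the scatter: the same change on two cores in this assay, a 4.0-fold higher number (0.60 log units; beyond the scatter) from compound 1 to compound 2 and a 22-fold lower number (1.35 log units; beyond the scatter) from compound 3 to compound 4, 89-fold (1.95 log units) apart, beyond the scatter of two such steps This shows that, for these two pairs, the step made by this change on one core did not carry over to the other, so it cannot simply be transferred between them; it does not show what in the cores produces the difference, and one pair per core gives no rule for any further core.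

The compounds shown leave open how other groups at the same place, such as fluoro, bromo, methyl or a nitrile, would behave on either core, and whether they would split between the cores in the same way. They also leave open whether the same reversal would appear with the ethynyl group replaced by a methyl group or a longer chain.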